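The compounds below may be only part of what the source reports. "The series", "measured", "known", "first", "only" and "open" are said of these compounds alone.

Measured so far in an ADME assay on MT4 cells (Homo sapiens) for cytotoxicity, read by MTT assay, with a stated time of 4 days; a lower number here means that less compound is tolerated, a higher number that more compound is tolerated:
- compound 1, `CCOC(=O)c1cnc(N2CCN(Cc3cccc(F)c3)CC2)nc1Oc1c(C)cc(-c2ccc(C#N)cc2)cc1C`, gives > 125000 nM, a limit of the assay.
- compound 2, `CCOC(=O)c1cnc(N2CCN(Cc3ccccc3C(=O)OC)CC2)nc1Oc1c(C)cc(-c2ccc(C#N)cc2)cc1C`, gives > 125000 nM, a limit of the assay.
- compound 3, `CCOC(=O)c1cnc(N2CCN(Cc3cccc(Br)c3)CC2)nc1Oc1c(C)cc(-c2ccc(C#N)cc2)cc1C`, gives > 125000 nM, a limit of the assay.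

Compound 3 therefore stands where every measured compound stands: at the limit of > 125000 nM in this assay, at which 3 of the 3 values shown sit. Among the compounds with values here, no compound reaches a number in this assay, so the three steps between them carry no readable size: a step that the two limits leave unreadable from compound 1 to compound 3, a step that the two limits leave unreadable from compound 1 to compound 2 and a step that the two limits leave unreadable from compound 2 to compound 3 are all left open by the two limits.

The next compound, compound 4, `CCOC(=O)c1cnc(N2CCN(Cc3ccc([N+](=O)[O-])cc3)CC2)nc1Oc1c(C)cc(-c2ccc(C#N)cc2)cc1C`, differs from compound 3 in one place: 4-nitrophenyl in place of 3-bromophenyl on a saturated chain carbon bound to an amine nitrogen in a ring. The measured steps that bear on this change are the three just named, each of which swaps one group on the saturated chain carbon bound to the amine nitrogen in the ring or on the aromatic carbon, and none of them moved a value off the limit.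

Compound 4 is expected to behave the same way, with a step that the limit leaves unreadable from compound 3 to compound 4 in this assay that most likely again ends at the limit. The estimate for compound 4 is 150000 nM, within 70000 nM to 400000 nM.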

Compound 4, half-maximal cytotoxic concentration: > 125000 nM
Compound 4: only a limit was reported; the forecaster's own chance of this, stated with the estimate: 85%; the middle value is on the limit's open side.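

In this assay compound 4 gives > 125000 nM, a limit of the assay, so its steps from compound 1, compound 2 and compound 3 cannot be read: the limit of > 125000 nM in this assay, at which 4 of the 4 values shown sit. The compounds shown leave open whether any change at this place moves the value off the limit, and by how much.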